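The source may report more compounds than this note shows. Statements on the series, on what has been measured and on what is new or still open speak of the compounds shown alone.

Measured so far:
- compound 1, `N#Cc1cc(Cl)cc(Oc2c(Cl)ccc3c2nnn3Cc2n[nH]c3nc(N)ccc23)c1`, in an in vivo ADME assay on the whole organism (strain Sprague-Dawley) for pharmacokinetics, with Rattus norvegicus as the target; a higher number here means that more of the compound sits outside the plasma, a lower number that more of the compound stays in the plasma: 4.4 L/kg
- compound 2, `N#Cc1cc(Cl)cc(Oc2c(Cl)ccc3c2cnn3Cc2n[nH]c3ncccc23)c1`, in this assay: 10.5 L/kg

Compound 2 gives the higher of the two numbers; its value stands beyond the scatter from that of compound 1, and the two compounds differ in more than one place, so no single change can be tied to that gap. Compound 3, `N#Cc1cc(Cl)cc(Oc2c(Cl)ccc3c2cnn3Cc2n[nH]c3nc(N)ccc23)c1`, is not yet measured. It differs from compound 2 by amino in place of hydrogen on an aromatic carbon, the same amino that compound 1 carries, while compound 3 keeps the core of compound 2. Among the measured compounds shown here, with no measured pair that differs only in this amino, the expected step from compound 2 to compound 3 is uncertain; a modest drop, near the edge of the scatter, is expected, a 1.6-fold lower number from compound 2 to compound 3 (0.21 log units; within the scatter). For compound 3 in this assay a value of 6.5 L/kg is estimated, within a range from 3.5 L/kg to 12 L/kg.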

Compound 3, volume of distribution in the Rattus norvegicus assay: 2.5 L/kg
Compound 3: the middle estimate sits 2.6-fold (0.41 log units) above what was measured; the whole stated range lies above it.
By their numbers in the Rattus norvegicus assay, from the lowest: compounds 3 and 1 (each within the scatter of the next); then compound 2.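

Amino in place of hydrogen on this aromatic carbon, next to the ring nitrogen, is the first single change that can be read on its own: in the Rattus norvegicus assay there is a 4.2-fold lower number from compound 2 to compound 3 (0.62 log units; beyond the scatter). In a physicochemical assay for solubility, at pH 2 (on this read-out lower numbers stand for lower solubility and higher numbers for higher solubility), compound 2 gives < 0.1 ug/mL, which is a limit of the assay and not a number. In the physicochemical assay compound 3 gives 40 ug/mL, so the one amino that lowers the volume of distribution also raises solubility: the measured solubility of compound 2, < 0.1 ug/mL, and of compound 3, 40 ug/mL, an at least 400-fold higher number (2.60 log units; beyond the scatter)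

Whether this amino step holds on the core of compound 1 stays open, as no partner of compound 1 with hydrogen at this place is shown. As far as these compounds go, how a methyl or a methoxy group on the same aromatic carbon would compare with amino also stays open.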